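The compounds below may be only part of what the source reports. "The series", "measured", "known", "first", "only" and "open" are said of these compounds alone.

Measured so far in an ADME assay on MDCK cells (Canis lupus familiaris) for cytotoxicity, read by microscopy, with a stated time of 48 h; on this read-out lower numbers stand for higher toxicity in this test and higher numbers for lower toxicity in this test:
- compound 1 `C[C@H]1[C@H](NCc2sccc2-c2ccsc2)C[C@H]2C[C@@H]1C2(C)C`: 12500 nM
- compound 2 `C[C@H]1[C@H](NCc2cc(C3CC3)cs2)C[C@H]2C[C@@H]1C2(C)C`: 25000 nM
- compound 3 `C[C@H]1[C@H](NCc2cnccn2)C[C@H]2C[C@@H]1C2(C)C`: see below

For compound 3 the result is a limit of the assay rather than a number, > 100000 nM. Among the two numbers, compound 2 and compound 1 sit within the usual scatter of each other, so the numbers give no order between them; the value of compound 2 is the higher of the two only nominally.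

The next compound, compound 4 `C=C(C)c1csc(CN[C@@H]2C[C@H]3C[C@@H]([C@H]2C)C3(C)C)c1`, is not yet measured. Compound 2 and compound 4 contain the same atoms, joined differently; the difference is confined to one group on the five-membered aromatic ring: 1-methylethenyl in place of cyclopropyl on an aromatic carbon

Among the measured compounds shown here, no measured pair reproduces this exchange, so its effect rests on no direct precedent. Both groups are small, carbon-only and without donors or acceptors, and on that ground the step is expected to stay within the scatter, with no clear direction: no change at the digits printed from compound 2 to compound 4 (within the scatter). Compound 4 is therefore estimated at 25000 nM, with a range from 8000 nM to 100000 nM, the upper end allowing that the assay may again return only a limit, as it did for compound 3.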

Compound 4, minimum cytotoxic concentration: 25000 nM
Beside the measured number, compound 4's estimate shows no gap at the digits printed; the range from low to high includes it.
By their numbers in this assay, from the lowest: compounds 1, 2 and 4 (each within the scatter of the next). At a limit, above all of these: compound 3.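

In this assay, 1-methylethenyl in place of cyclopropyl on an aromatic carbon, two ring bonds from the ring sulfur, gives no change at the digits printed from compound 2 to compound 4 (within the scatter). Among the compounds shown here, this is the first step that differs in one place, and it shows that opening the three-membered ring into a group with a double bond outside aromatic rings does not move the read-out at this position. Compound 3 remains at a limit, not a number, and this step says nothing about it: the limit of > 100000 nM in this assay, at which 1 of the 4 values shown sits.

The compounds shown leave open how an amine, a carboxylic acid or a longer chain on this aromatic carbon would read in this assay, and whether any of them would lie beyond the scatter from compound 2. With one step at this position, no trend for the position can be stated.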